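The compounds below may be only part of what the source reports. "The series", "measured", "known", "first", "only" and "open" are said of these compounds alone.

Measured so far:

Compound 1 `Fc1ccc(C2CC(c3ccc(Cl)s3)=NN2c2nc(-c3ccc(Cl)cc3)cs2)cc1` gives > 500 ug/mL in an ADME assay on NIH3T3 cells (Mus musculus) for cytotoxicity, read by XTT assay, with a stated time of 24 h (on this read-out higher numbers stand for weaker inhibition and lower numbers for stronger inhibition), a limit of the assay.
Compound 2 `Cc1ccc(-c2csc(N3N=C(c4ccc(C)s4)CC3c3ccc(F)cc3)n2)cc1` gives > 500 ug/mL in this assay, a limit of the assay.
Compound 3 `N#Cc1ccc(-c2csc(N3N=C(c4ccc(Cl)s4)CC3c3ccc(F)cc3)n2)cc1` gives > 500 ug/mL in this assay, a limit of the assay.

Compound 3 therefore has no number of its own in this assay, only a limit, and it shares that position with the two other measured compounds, since (the limit of > 500 ug/mL in this assay, at which 3 of the 3 values shown sit). None of the three shows any measurable cytotoxicity within the range the assay covers.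

Compound 4 `Cc1ccc(-c2csc(N3N=C(c4ccc(Cl)s4)CC3c3ccc(F)cc3)n2)cc1` has not yet been measured. Its difference from compound 3 is methyl in place of cyano on an aromatic carbon. Among the measured compounds shown here, the one measured step that touches the same position is a step that the two limits leave unreadable from compound 1 to compound 3, and because both of its ends are limits, its size cannot be read. So there is no measured step of known size to lean on, only the observation that every compound tested so far sits at the limit.

On that basis the expectation for compound 4 is no step beyond the scatter, with a number no higher from compound 3 to compound 4 (the limit leaves the size open) reflecting a value that most likely is again a limit. The estimated value for compound 4 in this assay is 500 ug/mL, within a range from 250 ug/mL to 1000 ug/mL.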

Compound 4, half-maximal inhibitory concentration: > 500 ug/mL
Compound 4 ended at the assay's limit; the forecaster's own chance of this, stated with the estimate: 85%; the middle value lies on the limit itself.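

Compound 4 stands at a limit of this assay, not at a number, as do compound 1, compound 2 and compound 3, so none of the steps joining compound 4 to these three can be read: (the limit of > 500 ug/mL in this assay, at which 4 of the 4 values shown sit). The compounds shown leave open how much cytotoxicity any of them has, and whether exchanging cyano, methyl or chloro changes it at all.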